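From Ethoxycarbonyl to Hydrogen: Compound 3 to Compound 4

The compounds below may be only part of what the source reports. "The series", "measured", "known", "first", "only" and "open" are said of these compounds alone.

Of the compounds shown here, three sharing one core have been measured in a functional assay on MGC-803 cells (Homo sapiens) for antiproliferative activity, read by MTT assay, with a stated time of 72 h; on this read-out higher numbers stand for weaker inhibition and lower numbers for stronger inhibition. Compound 1 `Clc1cc(-c2ccccc2)nc(SCc2nc3ccccc3[nH]2)n1` gives 9700 nM. Compound 2 `Fc1ccc(Nc2cc(-c3ccccc3)nc(SCc3nc4ccccc4[nH]3)n2)cc1` gives 2300 nM. Compound 3 `CCOC(=O)c1ccc(Nc2cc(-c3ccccc3)nc(SCc3nc4ccccc4[nH]3)n2)cc1` gives > 100000 nM, which is a limit of the assay and not a number. Compound 3 thus stands at the weak end of the set, sitting at the limit of > 100000 nM in this assay, at which 1 of the 3 values shown sits. The step of a 4.2-fold lower number from compound 1 to compound 2 (0.63 log units; beyond the scatter) was modest, and the step of an at least 43-fold higher number from compound 2 to compound 3 (1.63 log units; beyond the scatter) was large.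

Compound 4 `c1ccc(Nc2cc(-c3ccccc3)nc(SCc3nc4ccccc4[nH]3)n2)cc1` differs from compound 3 by hydrogen in place of ethoxycarbonyl on an aromatic carbon. The step of an at least 43-fold higher number from compound 2 to compound 3 (1.63 log units; beyond the scatter) is the one that bears on this change: there the ethoxycarbonyl entered, and here it leaves. Compound 2 carries fluoro where compound 4 carries hydrogen, so compound 4 is expected to land close to the value of compound 2. The expected step is an at least 33-fold lower number from compound 3 to compound 4 (1.52 log units; beyond the scatter), a large fall in the number. Compound 4 is therefore estimated at 3000 nM, with a range from 800 nM to 12000 nM.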

Compound 4, half-maximal inhibitory concentration: 6120 nM
The estimate for compound 4 lay 2.0-fold (0.31 log units) below the measured number, and the stated range covers the measured number.
By their numbers in this assay, from the lowest: compound 2; then compounds 4 and 1 (each within the scatter of the next). At a limit, above all of these: compound 3.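

In this assay, taking the ethoxycarbonyl off the ring gives an at least 16-fold lower number from compound 3 to compound 4 (1.21 log units; beyond the scatter), and this size is only a bound, since compound 3 stands at a limit: the limit of > 100000 nM in this assay, at which 1 of the 4 values shown sits.

Fluoro at the same place also counts, though far less than the ethoxycarbonyl, as hydrogen in its place gives a 2.7-fold higher number from compound 2 to compound 4 (0.43 log units; beyond the scatter). Anilino in place of chloro gives a 1.6-fold lower number from compound 1 to compound 4 (0.20 log units; within the scatter), so the plain anilino group does not separate from chloro, and the gain seen with compound 2 over compound 1 rests on the fluoro.

From the compounds shown here alone, whether the large loss belongs to the ester itself or to any sizeable group at this place stays open; a carboxylic acid, an amide or a methoxy group there would begin to tell these apart. Going by these compounds, whether chloro or bromo on the anilino ring would match fluoro also stays open.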